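The compounds below may be only part of what the source reports. "The series", "measured", "known", "first", "only" and "open" are said of these compounds alone.

In a functional assay on A-375 cells (Homo sapiens) for antiproliferative activity, read by CCK-8 assay, with a stated time of 72 h, tested at 8 uM (on this read-out higher numbers stand for a stronger effect at the one concentration tested and lower numbers for a weaker effect), three compounds built on one shared core have been measured. Compound 1 `COc1ccc(N2CCN(C(=S)SCc3ccc(C(=O)Nc4ccccc4N)cc3)CC2)cc1` gives 35.9%. Compound 2 `Nc1ccccc1NC(=O)c1ccc(CSC(=S)N2CCN(c3ccc(F)cc3)CC2)cc1` gives 76.3%, and compound 3 `Cc1ccc(N2CCN(C(=S)SCc3ccc(C(=O)Nc4ccccc4N)cc3)CC2)cc1` gives 26.4%. Compound 3 stands lowest of the three numbers, yet the step of a number 9.5 percentage points lower from compound 1 to compound 3 (within the scatter) is within the scatter, so compound 1 and compound 3 cannot be told apart, whereas the step of a number 49.9 percentage points lower from compound 2 to compound 3 (beyond the scatter) is beyond it and clearly separates compound 3 from compound 2.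

Compound 4 `Nc1ccccc1NC(=O)c1ccc(CSC(=S)N2CCN(c3ccncc3)CC2)cc1` has not yet been measured. It differs from compound 3 in one place: pyridin-4-yl in place of 4-methylphenyl on an amine nitrogen in a ring. Within the data shown here, none of the measured steps touches the aromatic ring itself; they only exchange the group on that ring. Two of them, a number 40.4 percentage points higher from compound 1 to compound 2 (beyond the scatter) and a number 49.9 percentage points lower from compound 2 to compound 3 (beyond the scatter), are large, while a number 9.5 percentage points lower from compound 1 to compound 3 (within the scatter) is small. These steps show that this part of the molecule can move the read-out strongly, but they give no direction for a ring nitrogen in place of a carbon bearing methyl. The expectation for compound 4 is therefore wide and leans only slightly upward. Compound 4 is estimated at 45%, with a range from 15% to 80%. This expected change corresponds to a number 18.6 percentage points higher from compound 3 to compound 4 (beyond the scatter).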

Compound 4, a percentage reported as inhibition, at one concentration (the size of the read-out at that concentration, not a potency): 90.7%
Estimate against measurement, compound 4: 45.7 percentage points below; measured number outside the range, above it.
By their numbers in this assay, from the lowest: compounds 3 and 1 (each within the scatter of the next); then compound 2; then compound 4.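

In this assay, among these compounds, the new result is the first to exchange the aromatic ring itself rather than only the group on it, and pyridin-4-yl on the ring amine nitrogen gives a number 64.3 percentage points higher from compound 3 to compound 4 (beyond the scatter) and a number 54.8 percentage points higher from compound 1 to compound 4 (beyond the scatter). Even against the best of the earlier groups, 4-fluorophenyl, the same exchange gives a number 14.4 percentage points higher from compound 2 to compound 4 (beyond the scatter), a modest step but one that makes compound 4 the highest of the four, with its steps to all three others beyond the scatter. This position therefore accepts an aromatic ring with a hetero atom and no group on it, and that ring outperforms all three substituted phenyl rings shown, although nothing measured here accounts for the gain.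

The compounds shown leave open whether the ring nitrogen or the absence of a group on the ring matters more, a question that plain phenyl would address, and whether the place of the nitrogen matters, as pyridin-3-yl or pyridin-2-yl would show. They also leave open how far the effect extends to a ring with two nitrogens, such as pyrimidin-5-yl, and how compound 4 would compare with the others across a range of concentrations rather than at the single one tested.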